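The source may report more compounds than this note shows. Statements on the series, on what has been measured and on what is new or still open speak of the compounds shown alone.

Measured so far in a functional assay on SK-N-SH cells (Homo sapiens) for inhibition, read by MTT assay, with a stated time of 72 h, tested at 50 uM; a lower number here means less inhibition of growth, a higher number more inhibition of growth at the concentration tested:

- Compound 1 `C=CCc1ccc(OCc2cn(-c3cccc([N+](=O)[O-])c3)nn2)c(O)c1`: 68.9%
- Compound 2 `C=CCc1cc(O)c(O)c(CN2CCC(C)CC2)c1`: 84.2%
- Compound 3 `C#CCOc1ccc(CC=C)cc1O`: 88.4%

Compound 2, at 84.2%, cannot be told apart from compound 3, at 88.4%, since the gap between them lies within the usual scatter of repeat measurements. Compound 1, at 68.9%, lies lower than compound 2, and that gap goes beyond the scatter.

The next compound to be tested is compound 4 `C=CCc1cc(O)c(O)c(CN2CCC(Cc3ccccc3)CC2)c1`, which is built from compound 2 by one change: phenyl in place of hydrogen on a saturated chain carbon bound to a saturated ring carbon.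

Going by the values given here, none of the three measured compounds differ from one another in just one place, so no measured step shows what such a change does in this assay. The expectation therefore starts from compound 2, whose 84.2% leaves limited room at the top of the scale. No shift beyond the scatter is expected in either direction. The estimated step of a number 0.8 percentage points higher from compound 2 to compound 4 (within the scatter) is correspondingly small. Compound 4 is expected at 85%, with an estimated range from 68% to 97%.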

Compound 4, percent growth inhibition at one concentration: 83.4%
For compound 4 the middle estimate is 1.6 percentage points above the measured one; the measured number falls inside the stated range.
By their numbers in this assay, from the lowest: compound 1; then compounds 4, 2 and 3 (each within the scatter of the next).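

Going by these compounds alone, the step of a number 0.8 percentage points lower from compound 2 to compound 4 (within the scatter) is the first measured change at this position in this assay, and it shows that growing methyl to benzyl at this spot leaves the read-out where it was, within ordinary repeat-to-repeat variation. A phenyl ring, with its added bulk of carbon atoms, can therefore stand in place of hydrogen on this saturated chain carbon bound to a saturated ring carbon without a detectable loss or gain of growth inhibition at the one concentration tested, though this rests on a single pair of compounds and says nothing yet about a general rule. Nothing else measured on these compounds accounts for why the result is flat, so no explanation can be offered for it.

What the compounds shown leave open is whether this position stays as undemanding when it carries a different kind of group, such as a carboxylic acid, an amine or a longer chain ending in phenyl. They also leave open whether compound 2 and compound 4 would still match at lower concentrations, where a full dose-response curve could separate them.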